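A pyridine in place of a fluorophenyl on the shared core

A few compounds are considered here, and "the series" means these few. Any claim that something is new, unique, unknown or untested is made for them only; others in the source may bear on it.

Three compounds have been measured in a functional assay on HCT-116 cells (Homo sapiens) for antiproliferative activity, read by MTT assay, with a stated time of 24 h; on this read-out lower numbers stand for stronger inhibition and higher numbers for weaker inhibition:
Compound 1, `COc1ccc(-c2noc(-c3ccc(F)cc3)n2)cc1O`, reaches only the limit of > 1000000 nM.
Compound 2, `COc1ccc(-c2noc(-c3ccc(F)cc3)n2)cc1OC1CCCC1`, gives 210000 nM.
Compound 3, `COc1ccc(-c2noc(Cc3c[nH]c4ccccc34)n2)cc1OC1CCCC1`, reaches only the limit of > 1000000 nM.

For the measured compounds named here, compound 2 therefore stands alone as the only compound with a number; the other two sit at the limit of > 1000000 nM in this assay, at which 2 of the 3 values shown sit. One step can be read among the measured compounds: an at least 4.7-fold lower number from compound 1 to compound 2 (0.67 log units; beyond the scatter). That step concerns the oxygen substituent on the outer ring, not the group studied here.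

Compound 4, `COc1ccc(-c2noc(-c3ccncc3)n2)cc1OC1CCCC1`, differs from compound 2 in a single place: pyridin-4-yl in place of 4-fluorophenyl on an aromatic carbon. Going by the values given here, no measured step touches that position, so nothing in the data points in either direction, and no step beyond the scatter is expected. Compound 4 is therefore estimated at 250000 nM, with a range from 70000 nM to 1000000 nM. The expected step is a 1.2-fold higher number from compound 2 to compound 4 (0.08 log units; within the scatter), and because compound 2 sits close to the limit of > 1000000 nM in this assay, at which 2 of the 3 values shown sit, there is a real chance that compound 4 also returns only a limit.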

Compound 4, half-maximal inhibitory concentration: > 1000000 nM
Compound 4 was reported as a limit; the forecaster's own chance of this, stated with the estimate: 35%; middle value at least 4.0-fold (0.60 log units) away from the limit.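

In this assay, for the compounds shown here, swapping 4-fluorophenyl for pyridin-4-yl on the aromatic carbon gives the first measured step at this position: an at least 4.7-fold higher number from compound 2 to compound 4 (0.67 log units; beyond the scatter). Together with the earlier step on the oxygen substituent, this shows that compound 2 gives a number only with both its cyclopentyl and its 4-fluorophenyl in place, since changing either one leaves just a limit. The size of the new step is only a minimum, because compound 4 returned a limit and not a number: the limit of > 1000000 nM in this assay, at which 3 of the 4 values shown sit.

From the compounds shown here alone, it remains open whether the loss goes with the missing fluorine or with the ring nitrogen that enters, a question that a plain phenyl at this place could help to settle. Going by these compounds, it is also open whether a 4-chlorophenyl or a pyridin-3-yl here would give a number at all.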